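Adding a Trifluoromethyl to the Phenyl of Compound 3

The source may hold more compounds than are shown below. What is called first, only, known or untested is meant among the compounds shown, and "the series" means these compounds.

Compound 3 `O=C(Nc1ccc(Oc2ccnc3[nH]ccc23)c(F)c1)c1cc(-c2ccccc2)ncn1` stands highest of the two compounds with a number in a functional assay on MCF7 cells (Homo sapiens) for cytotoxicity, read by MTT assay, with a stated time of 72 h; on this read-out lower numbers stand for stronger inhibition and higher numbers for weaker inhibition: compound 3 gives 4640 nM, whereas compound 2 `O=C(Nc1ccc(Oc2ccnc3[nH]ccc23)cc1)c1cc(-c2ccccc2)ncn1` gives 20 nM. Going by the values given here, the step of a 230-fold higher number from compound 2 to compound 3 (2.37 log units; beyond the scatter) is the only measured step in this set. Compound 1 `O=C(Nc1ccc(Oc2ccnc3[nH]ccc23)cc1)c1nccc(-c2ccc(F)cc2)n1`, which differs from both in more than one place, is reported in this assay as "not active" (no number reported).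

Compound 4 `O=C(Nc1ccc(Oc2ccnc3[nH]ccc23)c(F)c1)c1cc(-c2ccc(C(F)(F)F)cc2)ncn1` differs from compound 3 by trifluoromethyl in place of hydrogen on an aromatic carbon. Among the compounds with values here, no measured step covers this change: the one step from compound 2 to compound 3 concerns a fluoro on a different ring and does not bear on it. Compound 1, which also carries a substituent on its phenyl, offers no number and differs in several places, so it gives no guide either. With nothing to point in either direction, no step beyond the scatter is expected, and compound 4 is estimated to give 4600 nM, within a wide range from 900 nM to 25000 nM in this assay. The expected step is thus a 1.0-fold lower number from compound 3 to compound 4 (0.00 log units; within the scatter).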

Compound 4, half-maximal inhibitory concentration: 2840 nM
For compound 4 the middle estimate is 1.6-fold (0.21 log units) above the measured one; low and high end bracket the measured number.
By their numbers in this assay, from the lowest: compound 2; then compounds 4 and 3 (each within the scatter of the next).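

Going from phenyl to 4-(trifluoromethyl)phenyl gives a 1.6-fold lower number from compound 3 to compound 4 (0.21 log units; within the scatter) in this assay, so at this place, para to a large group, trifluoromethyl can stand in for hydrogen without a shift that clears the scatter. Going by these compounds alone, this is the first reading of a change on this ring, as the only earlier step, a 230-fold higher number from compound 2 to compound 3 (2.37 log units; beyond the scatter), concerns a fluoro on a different ring and is large, whereas this one is not. No measurement offered here accounts for this result.

Going by these compounds, whether trifluoromethyl would read the same on compound 2, which has no such fluoro, remains open, as the step is known only with that fluoro present. The compounds shown also leave open how an amine, a carboxylic acid or a methoxy group at this place would read.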